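The source may report more compounds than this note shows. Statements on the series, on what has been measured and on what is new or still open speak of the compounds shown alone.

Of the compounds shown here, three sharing one core have been tested in a functional assay on the whole organism (strain Albino Wistar) for inhibition, with Rattus norvegicus as the target, read by paw edema, with stated times of 1 h and 3 h, at a dose of 10 mg/kg by the oral route; a lower number here means less inhibition, a higher number more inhibition at the dose given (going by the name of the read-out). Compound 1 `Clc1cccc(-n2cc(CSc3nc4ccccc4s3)nn2)c1` gives 35%. Compound 2 `Fc1ccc(-n2cc(CSc3nc4ccccc4s3)nn2)cc1` gives 77.8%, the highest of the three numbers. Compound 3 `CCOc1ccc(-n2cc(CSc3nc4ccccc4s3)nn2)cc1` gives 38.3%. The step of a number 42.8 percentage points higher from compound 1 to compound 2 (beyond the scatter) and the step of a number 39.5 percentage points lower from compound 2 to compound 3 (beyond the scatter) both lie beyond the scatter, so compound 2 stands clearly at the top, with compound 3 nearest to it and compound 1 furthest away.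

Compound 4 `CC1(C)OCC(Cn2cc(CSc3nc4ccccc4s3)nn2)O1` has not yet been measured in this assay. Compared with compound 2 it carries (2,2-dimethyl-1,3-dioxolan-4-yl)methyl in place of 4-fluorophenyl on an aromatic nitrogen. Neither measured step involves a change of this kind: one swaps one aromatic ring for another on the same aromatic nitrogen, the other alters a substituent on that ring. What the two steps do show is that changing the group on this aromatic nitrogen moves the read-out by a large amount, and that compound 2 is the only one of the three to give a high number. Removing its whole 4-fluorophenyl and putting in a group of a quite different kind gives no ground to expect the high value to survive, so a large fall is expected, with wide uncertainty. Compound 4 is expected to give 40%, within a range from 20% to 65%, which would mean an expected step of a number 37.8 percentage points lower from compound 2 to compound 4 (beyond the scatter).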

Compound 4, a percentage reported as inhibition, in the whole organism at one dose (the size of the read-out at that dose, not a potency): 53.3%
Compound 4: middle estimate off by 13.3 percentage points, on the low side, within the range that was stated.
By their numbers in this assay, from the lowest: compounds 1 and 3 (each within the scatter of the next); then compound 4; then compound 2.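

In this assay the group on the aromatic nitrogen turns out not to need an aromatic ring for a clear effect to remain. Putting (2,2-dimethyl-1,3-dioxolan-4-yl)methyl on this nitrogen gives a number 24.5 percentage points lower from compound 2 to compound 4 (beyond the scatter) and so loses part of the high read-out, but the same group gives a number 18.3 percentage points higher from compound 1 to compound 4 (beyond the scatter) when it takes the place of 3-chlorophenyl. Among these compounds, then, an aromatic ring on this nitrogen is no guarantee of a better number than the non-aromatic group gives, and only the 4-fluorophenyl of compound 2 stays ahead of it, while no measurement at hand says what about these groups produces the two steps.

The compounds shown leave open which part of the new group counts: its five-membered ring, its two methyl groups or its two oxygen atoms, a question that an open 2,3-dihydroxypropyl chain or a plain butyl chain on the same nitrogen could help to settle. They also leave open how a group carrying an amine, such as a 2-(morpholin-4-yl)ethyl chain, or a carboxylic acid would behave at this position.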